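From carboxy to dimethylcarbamoyl: an amide step

This account rests on a few compounds, and the source may have more. Where it says the series, first, only, none or still open, it means among the compounds named here.

Compound 2 `O=C(O)COc1cc(=O)oc2cc(OCc3cccc(Cl)c3)ccc12` was tested in an assay on isolated protein (strain Sprague-Dawley) for inhibition of Amine oxidase [flavin-containing] A (Rattus norvegicus), read by spectrophotometry, with a stated time of 5 min, tested at 10 uM (on this read-out lower numbers stand for less inhibition and higher numbers for more inhibition at the one concentration tested (going by the name of the read-out)), where compound 2 gives 0%. Going by the values given here, the only other measured compound is compound 1 `CC(C)Oc1cc(=O)oc2cc(OCc3cccc(Cl)c3)ccc12`; in this assay compound 1 gives 3%. Among the compounds with values here, compound 2 therefore stands lowest of the two numbers, but the single measured step, a number 3 percentage points lower from compound 1 to compound 2 (within the scatter), lies within the scatter, so the two values cannot be ordered. Compound 3 `CN(C)C(=O)COc1cc(=O)oc2cc(OCc3cccc(Cl)c3)ccc12` differs from compound 2 by dimethylamino in place of hydroxy on a carbonyl carbon. Within the data shown here, no measured step alters the carbonyl carbon; the only step that bears on compound 3 is a number 3 percentage points lower from compound 1 to compound 2 (within the scatter), which left the read-out essentially unchanged, and both measured compounds sit at the bottom of the scale. Compound 3 is accordingly expected to show a number 3 percentage points higher from compound 2 to compound 3 (within the scatter), that is, no step beyond the scatter. Compound 3 is estimated at 3%, with a range from 0% to 15%.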

Compound 3, a percentage reported as inhibition, at one concentration (the size of the read-out at that concentration, not a potency): 10%
For compound 3 the middle estimate is 7 percentage points below the measured one; measured number inside the range.
By their numbers in this assay, from the lowest: compounds 2, 1 and 3 (each within the scatter of the next).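

In this assay, dimethylamino in place of hydroxy on a carbonyl carbon gives a number 10 percentage points higher from compound 2 to compound 3 (within the scatter) and so does not move the read-out beyond the scatter, even though the carboxy group becomes dimethylcarbamoyl and the hydrogen-bond donor of the hydroxy leaves. Against the isopropyl group on the same oxygen, the (dimethylcarbamoyl)methyl group gives a number 7 percentage points higher from compound 1 to compound 3 (within the scatter) and thus again no separable step, so isopropyl, carboxymethyl and (dimethylcarbamoyl)methyl at this position cannot be ordered. Nothing at hand explains these numbers.

On these data alone, whether an amine, a primary amide or a longer chain on this oxygen would lift the number beyond the scatter remains open. The other substituent on the shared core is the same in all three compounds, so what a change there would do is open as well.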